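Sulfonyl Aryl Variation in the Series: Compound 4

A few compounds are considered here, and "the series" means these few. Any claim that something is new, unique, unknown or untested is made for them only; others in the source may bear on it.

Compound 1 `COc1ccc(-c2cc(=O)c3c(OC)cc(OC)cc3[nH]2)cc1` carries hydrogen on the aromatic nitrogen of the shared core. In a functional assay on HepG2 cells (Homo sapiens) for antiproliferative activity, with a stated time of 72 h (on this read-out higher numbers stand for an effect only at larger amounts of compound and lower numbers for an effect already at smaller amounts), compound 1 reaches only a limit of the assay, > 31100 nM. Compound 2 `COc1ccc(-c2cc(=O)c3c(OC)cc(OC)cc3n2S(=O)(=O)c2ccc(C=O)cc2)cc1` carries (4-formylphenyl)sulfonyl on that nitrogen, and in this assay compound 2 again reaches only a limit, > 34400 nM. Compound 3 `COc1ccc(-c2cc(=O)c3c(OC)cc(OC)cc3n2S(=O)(=O)c2ccc(C)c([N+](=O)[O-])c2)cc1` has 4-methyl-3-nitrophenyl on the sulfonyl sulfur, and in this assay compound 3 also reaches only a limit, > 51700 nM. The steps a step that the two limits leave unreadable from compound 1 to compound 2 and a step that the two limits leave unreadable from compound 2 to compound 3 therefore cannot be sized; all three values sit at limits, (the limit of > 31100 nM in this assay, at which 1 of the 3 values shown sits), the limit of > 34400 nM in this assay, at which 1 of the 3 values shown sits, and (the limit of > 51700 nM in this assay, at which 1 of the 3 values shown sits), so compound 3 stands nowhere distinguishable from compounds 1 and 2 on the numbers shown.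

Compound 4 `COc1ccc(-c2cc(=O)c3c(OC)cc(OC)cc3n2S(=O)(=O)c2ccc(F)cc2)cc1` differs from compound 3 by 4-fluorophenyl in place of 4-methyl-3-nitrophenyl on a sulfonyl sulfur. The two measured steps that bear on this change are both unreadable, and the three compounds with and without a sulfonyl group on the aromatic nitrogen all fail to show an effect within the tested range. The expected step of an at least 1.0-fold lower number from compound 3 to compound 4 (0.01 log units; that floor lies within the scatter) is therefore none that can be read, and compound 4 is expected to remain at or near the limit of this assay. The estimate for compound 4 is 50000 nM, ranging from 20000 nM to 200000 nM, with a limit being the most likely report.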

Compound 4, half-maximal effective concentration: > 65500 nM
Compound 4: a limit, no number; the forecaster's own chance of this, stated with the estimate: 90%; middle value at least 1.3-fold (0.11 log units) from the limit.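

In this assay compound 4 gives > 65500 nM as a limit and not a number, so none of the steps to compound 4 from compound 1, compound 2 or compound 3 can be read. The compounds shown leave open whether any group on the aromatic nitrogen of the shared core alters antiproliferative activity.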